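The source may report more compounds than this note shows. Statements on the series, on what has been measured and on what is new or still open speak of the compounds shown alone.

Of the compounds shown here, two built on the shared core have been measured in an assay on isolated protein for displacement of a labelled ligand from metabotropic glutamate receptor 5 (Homo sapiens), with a stated time of 60 min, tested at 1 uM; on this read-out higher numbers stand for more inhibition at the one concentration tested (going by the name of the read-out) and lower numbers for less inhibition. Compound 1 `COc1ccc(S(=O)(=O)c2cnc3c(F)cccc3c2N2CCC(C)CC2)cc1` gives 67% in this assay, and this is the lower of the two numbers. Compound 2 `COc1ccc(S(=O)(=O)c2cnc3cc(F)ccc3c2N2CCC(C)CC2)cc1` gives 90% in this assay, a number higher by a margin that lies beyond the usual scatter, so compound 1 stands lowest of the two. Compound 3 `CC1CCN(c2c(S(=O)(=O)c3ccc(F)c(Cl)c3)cnc3c(F)cccc23)CC1` has not yet been measured. Compared with compound 1 it differs in one place: 3-chloro-4-fluorophenyl in place of 4-methoxyphenyl on a sulfonyl sulfur. Going by the values given here, no measured pair shows this particular change, so its effect cannot be read from these compounds. One would expect at most a small step in this assay, with the direction uncertain and possibly none beyond the scatter. Compound 3 is estimated to give 72% in this assay, with a range from 45% to 92%. This estimate means an expected a number 5 percentage points higher from compound 1 to compound 3 (within the scatter) in this assay.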

Compound 3, a percentage reported as inhibition, at one concentration (the size of the read-out at that concentration, not a potency): 95%
For compound 3 the middle estimate is 23 percentage points below the measured one; measured number above the stated range.
By their numbers in this assay, from the lowest: compound 1; then compounds 2 and 3 (each within the scatter of the next).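

In this assay, replacing 4-methoxyphenyl with 3-chloro-4-fluorophenyl on the sulfonyl sulfur gives a number 28 percentage points higher from compound 1 to compound 3 (beyond the scatter) and so shows that the group at this place can shift the read-out on the shared core. Until now, both measured compounds carried 4-methoxyphenyl there, so this place had not been tested. The result also shows that 4-methoxyphenyl is not needed for high inhibition on the core of compound 1, though nothing at hand explains the size of the step.

The compounds shown leave open whether the chlorine or the fluorine carries this step, which 3-chlorophenyl and 4-fluorophenyl would separate, and how a phenyl ring bearing an amine or a carboxylic acid would behave at this place. They also leave open whether the same change would give a similar step on the core of compound 2.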